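Trifluoromethoxy in place of nitro on compound 1

The compounds below may be only part of what the source reports. "The series", "measured", "known", "first", "only" and "open" are said of these compounds alone.

In an ADME assay for permeability, using PAMPA, at pH 7.4 (a higher number here means that the compound crosses the layer faster, a lower number that the compound crosses the layer more slowly), compound 1 (`Cc1cc(NC(=O)Nc2cccc([N+](=O)[O-])c2)c2ccccc2n1`) gives 42 10^-6 cm/s and compound 3 (`Cc1cc(NC(=O)Nc2cnc3ccccc3c2)c2ccccc2n1`) gives 46 10^-6 cm/s so the two lie within the scatter of each other. Compound 2 (`COc1ccc(NC(=O)Nc2cc(C)nc3ccccc23)cc1OC`) gives 552 10^-6 cm/s and stands beyond the scatter above both. Compound 4 (`Cc1cc(NC(=O)Nc2cccc(OC(F)(F)F)c2)c2ccccc2n1`) is unmeasured and has trifluoromethoxy in place of nitro on an aromatic carbon. Within the data shown here, no measured pair isolates this change. Among the measured compounds shown here, compound 2 at 552 10^-6 cm/s shows only that much higher numbers are reachable on the shared core. An upward step in this assay is therefore expected, probably beyond the scatter, and is estimated as a 4.5-fold higher number from compound 1 to compound 4 (0.66 log units; beyond the scatter) on this limited evidence. Compound 4 is expected at 190 10^-6 cm/s (estimated range 80 10^-6 cm/s to 500 10^-6 cm/s).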

Compound 4, apparent permeability: 464 10^-6 cm/s
For compound 4 the middle estimate is 2.4-fold (0.39 log units) below the measured one; the range from low to high includes it.
By their numbers in this assay, from the lowest: compounds 1 and 3 (each within the scatter of the next); then compounds 4 and 2 (each within the scatter of the next).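

In this assay, among these compounds, trifluoromethoxy in place of nitro on an aromatic carbon gives an 11-fold higher number from compound 1 to compound 4 (1.04 log units; beyond the scatter), the first step that isolates a single change. Among the compounds shown here, the substituent at this place on the shared core can therefore shift the read-out strongly, which the earlier compounds, differing in more than one place, could not show. Nothing available accounts for the size of this step. Open, going by these compounds, is where methoxy, trifluoromethyl, an amine or a carboxylic acid at this place would fall relative to compound 1 and compound 4. Also open, on these data alone, is whether the same exchange gives a similar step at other places on the ring.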